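The source may report more compounds than this note shows. Statements on the series, on what has been measured and on what is new or still open speak of the compounds shown alone.

The measured compounds and their values in a functional assay on A498 cells (Homo sapiens) for cytotoxicity, read by MTT assay, with a stated time of 24 h; on this read-out lower numbers stand for stronger inhibition and higher numbers for weaker inhibition:

Compound 1, `CC1=C(SCCC(=O)OC(C[Se]C2=C(C)C(=O)c3ccccc3C2=O)C(=O)NC(C)(C)C)C(=O)c2ccccc2C1=O`, gives 3000 nM.
Compound 2, `CC1=C(SCCC(=O)OC(CC[Se]c2ccccc2)C(=O)NCCCCCC(=O)OCc2ccccc2)C(=O)c2ccccc2C1=O`, reaches only the limit of the assay, > 100000 nM.
Compound 3, `CC1=C([Se]CC(OC(=O)CNC(=O)OC(C)(C)C)C(=O)NCCCCCC(=O)OCc2ccccc2)C(=O)c2ccccc2C1=O`, gives 7000 nM.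

Going by the values given here, compound 2 therefore stands apart from the other two: it is the one value that is a limit rather than a number, (the limit of > 100000 nM in this assay, at which 1 of the 3 values shown sits), while compound 1 and compound 3 each give a measured number. Nothing more than that bound is known of where compound 2 truly lies.

Compound 4, `CC1=C(SCCC(=O)OC(C[Se]c2ccccc2)C(=O)NCCCCCC(=O)OCc2ccccc2)C(=O)c2ccccc2C1=O`, differs from compound 2 in a single place: a group of 7 heavy atoms (6 carbon, 1 selenium; one six-membered aromatic ring of carbon only) in place of a group of 8 heavy atoms (7 carbon, 1 selenium; one six-membered aromatic ring of carbon only), on a saturated chain carbon, two bonds along the chain from a carbonyl carbon and an oxygen next to a carbonyl group. Among the compounds with values here, no pair of measured compounds shares this change, so the size of its step cannot be read from the data. Compound 1 carries the shorter link to the selenium and gives 3000 nM, which leaves room for a gain. The step in this assay from compound 2 to compound 4 is expected to be a gain, an at least 2.5-fold lower number from compound 2 to compound 4 (0.39 log units; beyond the scatter), though the limit on compound 2 makes its size uncertain. Compound 4 is estimated at 40000 nM, between 8000 nM and 100000 nM.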

Compound 4, half-maximal inhibitory concentration: > 100000 nM
Compound 4 ended at the assay's limit; the forecaster's own chance of this, stated with the estimate: 35%; middle value at least 2.5-fold (0.39 log units) away from the limit.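

No step can be read from compound 2 to compound 4 in this assay, because each compound gives a limit of the assay rather than a number: the limit of > 100000 nM in this assay, at which 2 of the 4 values shown sit.

The compounds shown leave open whether the group of 7 heavy atoms, in place of the group of 8 heavy atoms, changes cytotoxicity at all.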